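This account rests on a few compounds, and the source may have more. Where it says the series, first, only, none or still open, it means among the compounds named here.

Going by the values given here, the two compounds measured so far share one core. Compound 1 `Clc1ccc(C2CC(c3ccc(N4CCCCC4)cc3)=NN2c2nc(-c3ccccc3)cs2)cc1` gives 65800 nM in a functional assay on A-375 cells (Homo sapiens) for antiproliferative activity, read by MTT assay, with a stated time of 72 h; a higher number here means a weaker inhibitor, a lower number a stronger inhibitor. Compound 2 `Fc1ccc(-c2csc(N3N=C(c4ccc(N5CCCCC5)cc4)CC3c3ccc(Cl)cc3)n2)cc1` gives 71400 nM in this assay. Compound 2 stands at the higher of the two numbers, but the step of a 1.1-fold higher number from compound 1 to compound 2 (0.04 log units; within the scatter) lies within the scatter, so the two values cannot be told apart. Compound 3 `Clc1ccc(-c2csc(N3N=C(c4ccc(N5CCCCC5)cc4)CC3c3ccc(Cl)cc3)n2)cc1` has not yet been measured in this assay. It differs from compound 2 by chloro in place of fluoro on an aromatic carbon. Among the compounds with values here, only one measured step bears on this change, the step of a 1.1-fold higher number from compound 1 to compound 2 (0.04 log units; within the scatter), which shows that placing fluoro at this position moved the number by no more than the scatter. Within the data shown here, no step from fluoro to chloro has been measured here, so the direction of any shift in this assay is open, and a step beyond the scatter is not expected in either direction. Because a 1.1-fold higher number from compound 1 to compound 2 (0.04 log units; within the scatter) stayed within the scatter, compound 3 is expected to give 65000 nM, with a range from 30000 nM to 150000 nM. The expected step is a 1.1-fold lower number from compound 2 to compound 3 (0.04 log units; within the scatter), which amounts to no change beyond the scatter.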

Compound 3, half-maximal inhibitory concentration: > 100000 nM
Compound 3 was reported as a limit; the forecaster's own chance of this, stated with the estimate: 10%; middle value at least 1.5-fold (0.18 log units) away from the limit.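

Compound 3 is the first of the compounds shown for which this position gives a limit and not a number in this assay: the limit of > 100000 nM in this assay, at which 1 of the 3 values shown sits. Chloro in place of fluoro gives an at least 1.4-fold higher number from compound 2 to compound 3 (0.14 log units; that floor lies within the scatter) and chloro in place of hydrogen gives an at least 1.5-fold higher number from compound 1 to compound 3 (0.18 log units; that floor lies within the scatter), so both steps are known only as floors, and neither floor lies beyond the scatter. The earlier step of a 1.1-fold higher number from compound 1 to compound 2 (0.04 log units; within the scatter) had a measured size at both ends, whereas these two steps have no upper bound, so the size of the change to chloro on this carbon cannot be read from them, and a step beyond the scatter is neither shown nor ruled out.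

Going by these compounds, how far the true value of compound 3 lies past its limit stays open, and with it whether chloro and fluoro truly differ at this position. Also open, on these data alone, is how the number would respond to a group of another kind on this carbon, such as methoxy, an amine or a carboxylic acid, since only hydrogen, fluoro and chloro appear there.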